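The source may report more compounds than this note shows. Statements on the series, on what has been measured and on what is new or still open speak of the compounds shown alone.

For the measured compounds named here, in an assay on HEK293 cells for inhibition of Voltage-dependent T-type calcium channel subunit alpha-1G (Homo sapiens), read by fluorescence, tested at 10 uM (a lower number here means less inhibition, a higher number more inhibition at the concentration tested (going by the name of the read-out)), compound 2 `CCCc1nc(-c2ccccc2)c(CNCCCN2CCN(c3ccccc3Cl)CC2)o1` gives 64.7%, the higher of the two numbers so far; compound 1 `CCCc1nc(-c2ccccc2)c(CNCCCN2CCN(c3ccc(OC)cc3)CC2)o1` gives 42.1%, and the step of a number 22.6 percentage points higher from compound 1 to compound 2 (beyond the scatter) lies beyond the scatter. Compound 3 `CCCc1nc(-c2ccccc2)c(CNCCCN2CCN(c3cccc(Cl)c3)CC2)o1` is the next member; the change is 3-chlorophenyl in place of 2-chlorophenyl on an amine nitrogen in a ring. Going by the values given here, no measured step compares a 2-chlorophenyl with a 3-chlorophenyl, so the single step in hand shows only that the group on the ring nitrogen moves the read-out by a modest amount. The step of a number 6.7 percentage points lower from compound 2 to compound 3 (within the scatter) is expected to stay within the scatter. For compound 3 the expected value is 58%, within 40% to 75%.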

Compound 3, a percentage reported as inhibition, at one concentration (the size of the read-out at that concentration, not a potency): 65.9%
Estimate against measurement, compound 3: 7.9 percentage points below; the measured number falls inside the stated range.
By their numbers in this assay, from the lowest: compound 1; then compounds 2 and 3 (each within the scatter of the next).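

In this assay, the step of a number 1.2 percentage points higher from compound 2 to compound 3 (within the scatter) leaves 3-chlorophenyl and 2-chlorophenyl on the ring nitrogen indistinguishable, so this change does not separate the two groups. The step of a number 23.8 percentage points higher from compound 1 to compound 3 (beyond the scatter) shows that 3-chlorophenyl, like 2-chlorophenyl, stands apart from 4-methoxyphenyl at this place. No measurement bears on the cause of either step.

Open, on these data alone, is what 4-chlorophenyl or 3-methoxyphenyl gives here, which would separate the effect of the substituent from that of its ring location. Also open, as far as these compounds go, is how unsubstituted phenyl or pyridyl reads on the same nitrogen.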